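The compounds below may be only part of what the source reports. "The series", "measured", "known", "first", "only" and "open" are said of these compounds alone.

In a functional assay on A2780 cells (Homo sapiens) for antiproliferative activity, read by MTT assay, with a stated time of 48 h (on this read-out lower numbers stand for stronger inhibition and higher numbers for weaker inhibition), compound 1 `COc1ccc(C(=O)c2ccc(OC)c3c2C=CC(C)(C)O3)c(NC(=O)CBr)c1` gives 2150 nM, compound 2 `COc1ccc(C(=O)c2ccc(OC)c3c2OC(C)(C)C=C3)c(NC(=O)CO)c1` gives 100 nM and compound 3 `COc1ccc(C(=O)c2ccc(OC)c3c2OC(C)(C)C=C3)c(NC(=O)CN)c1` gives 380 nM, the second highest of these three numbers. Compound 4 `CCNCC(=O)Nc1cc(OC)ccc1C(=O)c1ccc(OC)c2c1OC(C)(C)C=C2` is still unmeasured. It differs from compound 3 in one place: ethyl in place of hydrogen on an amine nitrogen, with ethyl in place of hydrogen on an amine nitrogen. Going by the values given here, only one measured step involves this amino group: a 3.8-fold higher number from compound 2 to compound 3 (0.58 log units; beyond the scatter), with amino in place of hydroxy. Compound 1 is joined to neither neighbour by a single-place step, so it sets only the spread of the numbers. Among the compounds with values here, no measured compound carries a substituent on the amine nitrogen, so direct precedent is lacking. The step to compound 3 suggests that a change at this chain end can exceed the scatter, but only modestly. A step of similar or smaller size is therefore expected in this assay, leaning weakly towards a higher number. The expected change is a 1.3-fold higher number from compound 3 to compound 4 (0.12 log units; within the scatter). Compound 4 is estimated at 500 nM, with an expected range of 150 nM to 1600 nM.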

Compound 4, half-maximal inhibitory concentration: 1980 nM
Compound 4: the middle estimate sits 4.0-fold (0.60 log units) below what was measured; the whole stated range lies below it.
By their numbers in this assay, from the lowest: compound 2; then compound 3; then compounds 4 and 1 (each within the scatter of the next).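

In this assay, going by these compounds alone, the amine nitrogen at the chain end proves sensitive to substitution, which the earlier compounds could not show: ethyl in place of hydrogen gives a 5.2-fold higher number from compound 3 to compound 4 (0.72 log units; beyond the scatter) and is a step beyond the scatter. This step runs in the same direction as the change from hydroxy to amino (a 3.8-fold higher number from compound 2 to compound 3 (0.58 log units; beyond the scatter)), and ethylamino in place of hydroxy gives a large overall step (a 20-fold higher number from compound 2 to compound 4 (1.30 log units; beyond the scatter)). Nothing available gives a cause for these steps.

With only hydrogen and ethyl shown on this nitrogen, it remains open whether a methyl group would cost less or a longer chain such as propyl would cost more. Also open, as far as these compounds go, is how a ring amine such as morpholine, or a methoxy group in place of hydroxy, would compare at this chain end.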